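A furan amide traded for a chloropyrimidine amide

A few compounds are considered here, and "the series" means these few. Any claim that something is new, unique, unknown or untested is made for them only; others in the source may bear on it.

Compound 2 `O=C(NCCC1CC1)c1ccc(N2CCN(C(=O)c3ccoc3C(F)(F)F)CC2)nn1` carries 2-(trifluoromethyl)furan-3-yl on the carbonyl carbon, and in an assay on microsomes from liver (strain ICR) for inhibition of acyl-CoA desaturase 1 (Mus musculus), read by scintillation counting, with a stated time of 20 h (on this read-out lower numbers stand for stronger inhibition and higher numbers for weaker inhibition), compound 2 gives 260 nM. Compound 2 holds the only number shown, as the other value is a limit. Compound 1 `O=C(NCCC1CC1)c1ccc(N2CCN(C(=O)C3CC3C(F)(F)F)CC2)nn1` in this assay gives > 1000 nM, a limit of the assay (the limit of > 1000 nM in this assay, at which 1 of the 2 values shown sits). For the measured compounds named here, the one measured step, an at least 3.8-fold lower number from compound 1 to compound 2 (0.58 log units; beyond the scatter), shows that changing the ring on the carbonyl carbon can move the read-out by at least a modest amount. Compound 3 `O=C(NCCC1CC1)c1ccc(N2CCN(C(=O)c3cnc(Cl)nc3C(F)(F)F)CC2)nn1` is not yet measured; it differs from compound 2 by 2-chloro-4-(trifluoromethyl)pyrimidin-5-yl in place of 2-(trifluoromethyl)furan-3-yl on a carbonyl carbon. That step exchanges one aromatic ring for another on the same carbonyl carbon, so the earlier step gives only a loose guide and no clear direction. Compound 3 is therefore expected to land near compound 2, a 1.4-fold lower number from compound 2 to compound 3 (0.16 log units; within the scatter). For compound 3 the estimate in this assay is 180 nM, ranging from 45 nM to 700 nM.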

Compound 3, half-maximal inhibitory concentration: 321 nM
Compound 3: middle estimate off by 1.8-fold (0.25 log units), on the low side; measured number inside the range.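

In this assay the place on the carbonyl carbon takes a six-membered aromatic ring with 2 hetero atoms as readily as a five-membered one with 1 hetero atom: putting 2-chloro-4-(trifluoromethyl)pyrimidin-5-yl in for 2-(trifluoromethyl)furan-3-yl gives a 1.2-fold higher number from compound 2 to compound 3 (0.09 log units; within the scatter). The same group also stands apart from 2-(trifluoromethyl)cyclopropyl, with an at least 3.1-fold lower number from compound 1 to compound 3 (0.49 log units; beyond the scatter), which shows that the earlier step was not peculiar to the furan ring. Compound 1 remains a limit and not a number: the limit of > 1000 nM in this assay, at which 1 of the 3 values shown sits.

All three groups carry trifluoromethyl, and the compounds shown leave open how a phenyl ring without it, or with a methyl group or a nitrile in its place, would read in this assay. As far as these compounds go, the chlorine and the ring nitrogens also enter together, and their separate contributions remain open.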